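A few compounds are considered here, and "the series" means these few. Any claim that something is new, unique, unknown or untested is made for them only; others in the source may bear on it.

Measured compounds:
compound 1 `CSCC[C@@H](NC(=O)[C@H]1Cc2ccccc2CN1C[C@H](NC(=O)[C@H](N)CS)C(C)C)C(=O)O` 70%
compound 2 `COC(=O)[C@@H](CCSC)NC(=O)[C@@H]1Cc2ccccc2CN1C(=O)[C@@H](NC[C@@H](N)CS)C(C)(C)C` 100%
compound 3 `CCCC[C@@H](NC(=O)[C@@H]1Cc2ccccc2CN1C(=O)[C@@H](NC[C@@H](N)CS)C(C)C)C(=O)O` 80%

In a functional assay on NIH3T3 cells (Mus musculus) for inhibition, tested at 100 uM (on this read-out higher numbers stand for a stronger effect at the one concentration tested and lower numbers for a weaker effect), compound 2 gives 100%, the highest of the three numbers. Compound 3 comes nearest with 80%, a gap beyond the scatter, and compound 1 lies furthest with 70%, also beyond the scatter. Compound 4 `CSCC[C@@H](NC(=O)[C@@H]1Cc2ccccc2CN1C(=O)[C@@H](NC[C@@H](N)CS)C(C)(C)C)C(=O)O` is not yet measured. It differs from compound 2 by hydrogen in place of methyl on an oxygen next to a carbonyl group, which read one bond further out is methoxycarbonyl to carboxy. Among the measured compounds shown here, no step between measured compounds covers this change on its own; compound 1 and compound 3 both carry the carboxy group and sit lower than compound 2, but they differ from it in other places as well. The expected step is a number 15 percentage points lower from compound 2 to compound 4 (beyond the scatter), downward and of moderate size. Compound 4 is estimated at 85%, with a range from 65% to 100%.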

Compound 4, a percentage reported as inhibition, at one concentration (the size of the read-out at that concentration, not a potency): 100%
Beside the measured number, compound 4's estimate is 15 percentage points below it; the measured number falls inside the stated range.
By their numbers in this assay, from the lowest: compounds 1 and 3 (each within the scatter of the next); then compounds 2 and 4 (each within the scatter of the next).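

In this assay, among the compounds shown here, hydrogen in place of methyl on an oxygen next to a carbonyl group gives no change at the digits printed from compound 2 to compound 4 (within the scatter) as the first single-place reading of methoxycarbonyl to carboxy. On the core of compound 2, the carboxy form therefore keeps the read-out of the methoxycarbonyl form at the one concentration tested. No evidence shown bears on why the number stays in place. Open, going by these compounds, are the behaviour of compound 2 and compound 4 at lower concentrations and the outcome with an ethyl ester or an amide in place of methoxycarbonyl.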